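Replacing the Phenethyl Arm with a Nitrile

A few compounds are considered here, and "the series" means these few. Any claim that something is new, unique, unknown or untested is made for them only; others in the source may bear on it.

Three measured compounds share one core and differ only in what the benzylic ether carries. Compound 1 `COc1cc(OCc2cccc(COc3ccccc3)c2)c2cc(-c3cn4nc(OC)sc4n3)oc2c1` gives 3.2 nM in a functional assay on HEK293 cells for antagonist activity at proteinase-activated receptor 4 (Homo sapiens), read by FLIPR and calcium flux, with a stated time of 30 min; on this read-out lower numbers stand for stronger inhibition and higher numbers for weaker inhibition. Compound 2 `COc1cc(OCc2ccccc2OCc2ccccc2)c2cc(-c3cn4nc(OC)sc4n3)oc2c1` gives 3.2 nM in this assay. Compound 3 `COc1cc(OCc2cccc(CCc3ccccc3)c2)c2cc(-c3cn4nc(OC)sc4n3)oc2c1` gives 2.4 nM in this assay, the lowest of the three numbers, although its gaps to compound 1 and to compound 2 both lie within the scatter of repeated measurements, so no order among the three can be claimed. Among the compounds with values here, the only step measured in a single place, a 1.3-fold lower number from compound 1 to compound 3 (0.12 log units; within the scatter), is likewise within the scatter.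

Compound 4 `COc1cc(OCc2cccc(C#N)c2)c2cc(-c3cn4nc(OC)sc4n3)oc2c1` makes a far larger change: cyano in place of phenethyl on an aromatic carbon. The measured step from phenoxy to benzyl exchanged one ring-bearing arm for another and does not speak to removing the arm altogether; all three measured compounds keep a second six-membered aromatic ring of carbon only, and nothing here tests whether that ring is needed. The step of an 8.3-fold higher number from compound 3 to compound 4 (0.92 log units; beyond the scatter) is therefore expected to move toward a higher number in this assay, with wide uncertainty. Compound 4 is estimated at 20 nM, expected to fall between 3 nM and 150 nM.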

Compound 4, half-maximal inhibitory concentration: 0.98 nM
Compound 4: the middle estimate sits 20-fold (1.31 log units) above what was measured; measured number below the stated range.
By their numbers in this assay, from the lowest: compound 4; then compounds 3, 1 and 2 (each within the scatter of the next).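

At this aromatic carbon the cyano group of compound 4 takes the place of a whole arm, and this assay records a 2.4-fold lower number from compound 3 to compound 4 (0.39 log units; beyond the scatter) and, against the phenoxymethyl arm, a 3.3-fold lower number from compound 1 to compound 4 (0.51 log units; beyond the scatter) with both steps modest but beyond the scatter. The earlier compounds shown here only exchanged one ring-bearing arm for another, whereas these steps show that the six-membered aromatic ring of carbon only carried by those arms can be removed entirely at this position, with stronger inhibition rather than a loss. Nothing available here accounts for this result.

As far as these compounds go, it remains open whether the lower number belongs to the nitrile itself or follows simply from losing the arm, a question on which a plain hydrogen, a methyl group or a carboxylic acid on the same carbon would bear. Also open is how far the group here can grow before the number changes again, for instance with a methoxy group, an amide or a longer chain ending in an amine, since the compounds shown jump straight from the ring-bearing arms to the nitrile.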